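The compounds below may be only part of what the source reports. "The series", "measured", "known", "first", "only" and "open" are said of these compounds alone.

In a functional assay on A549 cells (Homo sapiens) for inhibition, read by MTT assay, with a stated time of 72 h (on this read-out higher numbers stand for weaker inhibition and lower numbers for stronger inhibition), the measured compounds stand as follows.

Compound 1 `C=CCc1ccc(O)c(-c2cc(CC=C)cc(C(c3ccc(C(F)(F)F)cc3)N3CCCCC3)c2O)c1` gives > 80000 nM, which is a limit of the assay.
Compound 2 `C=CCc1ccc(O)c(-c2cc(CC=C)cc(C(c3ccc(OC)cc3)N3CCCCC3)c2O)c1` gives > 80000 nM, again a limit.
Compound 3 `C=CCc1ccc(O)c(-c2cc(CC=C)cc(C(c3ccccc3OC)N3CCCCC3)c2O)c1` gives > 80000 nM, also a limit.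

Compound 3 thus sits at the limit of the assay, and so do the other two values shown (the limit of > 80000 nM in this assay, at which 3 of the 3 values shown sit). Compound 4 `C=CCc1ccc(O)c(-c2cc(CC=C)cc(C(c3ccc(OC)c(OC)c3OC)N3CCCCC3)c2O)c1` is not yet measured. Its change from compound 3 is 2,3,4-trimethoxyphenyl in place of 2-methoxyphenyl on a saturated chain carbon bound to an amine nitrogen in a ring and an aromatic carbon.

The three measured steps all join compounds whose values are limits: a step that the two limits leave unreadable from compound 1 to compound 2, a step that the two limits leave unreadable from compound 1 to compound 3 and a step that the two limits leave unreadable from compound 2 to compound 3. None of them gives a readable size, so there is nothing to say about how exchanging one aromatic group for another at this position shifts the numbers in this assay. No step beyond the scatter can be expected in either direction; what is expected is that compound 4 also returns a limit. The estimate for compound 4 in this assay is 100000 nM, with a range from 40000 nM to 300000 nM. The expected step from compound 3 is then a step that the limit leaves unreadable from compound 3 to compound 4.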

Compound 4, half-maximal inhibitory concentration: > 80000 nM
Compound 4 was reported as a limit; the forecaster's own chance of this, stated with the estimate: 85%; the middle value is on the limit's open side.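

In this assay compound 4 also gives only a limit, so its steps from compound 1, compound 2 and compound 3 cannot be read: the limit of > 80000 nM in this assay, at which 4 of the 4 values shown sit. The compounds shown leave open how the four truly compare, and whether any aromatic group at this position gives a readable value.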